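Trimming the sulfonyl substituent: from isopropyl back toward methyl

The source may hold more compounds than are shown below. What is called first, only, known or untested is meant among the compounds shown, and "the series" means these compounds.

Measured compounds:
Compound 1, `COc1ccccc1-n1nc(C2CCN(S(C)(=O)=O)CC2)cc1-c1ccc(Cl)cc1`: 45%
Compound 2, `COc1ccccc1-n1nc(C2CCN(S(=O)(=O)C(C)C)CC2)cc1-c1ccc(Cl)cc1`: 19%

For the measured compounds named here, in an ADME assay on microsomes from liver (Rattus norvegicus) for metabolic stability, with a stated time of 10 min (a higher number here means that more of the compound is left, a lower number that less of the compound is left), compound 2 gives 19%, the lower of the two numbers known so far; its nearest neighbour is compound 1, which gives 45%. Going by the values given here, the one measured step, a number 26 percentage points lower from compound 1 to compound 2 (beyond the scatter), came with isopropyl in place of methyl on a sulfonyl sulfur and lies beyond the scatter.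

Compound 3, `CCS(=O)(=O)N1CCC(c2cc(-c3ccc(Cl)cc3)n(-c3ccccc3OC)n2)CC1`, has not yet been measured. It differs from compound 2 by hydrogen in place of methyl on a saturated chain carbon bound to a saturated chain carbon and a sulfonyl sulfur. This change runs back along the same line as the step from compound 1 to compound 2, but only part of the way, since ethyl stands between methyl and isopropyl. A recovery of part of that loss is therefore expected, so compound 3 is estimated at 32%, within a range from 18% to 48%, which corresponds to an expected step of a number 13 percentage points higher from compound 2 to compound 3 (beyond the scatter).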

Compound 3, percent of the compound remaining: 22%
Beside the measured number, compound 3's estimate is 10 percentage points above it, and the stated range covers the measured number.
By their numbers in this assay, from the lowest: compounds 2 and 3 (each within the scatter of the next); then compound 1.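

In this assay, the removal of one methyl gives a number 3 percentage points higher from compound 2 to compound 3 (within the scatter), so isopropyl and ethyl on the sulfonyl sulfur cannot be told apart by this read-out. The other step, a number 23 percentage points lower from compound 1 to compound 3 (beyond the scatter), places the measured difference at the change between methyl and ethyl, with methyl in place of hydrogen on a saturated chain carbon bound to a sulfonyl sulfur, so the three compounds do not follow an even progression from methyl through ethyl to isopropyl. No available evidence accounts for this pattern.

The compounds shown leave open whether a longer chain such as n-propyl, or a cyclopropyl or trifluoromethyl group, on the sulfonyl sulfur would match methyl or ethyl in this assay here. They also leave open whether an amide carbonyl in place of the sulfonyl would show the same steps.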